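A few compounds are considered here, and "the series" means these few. Any claim that something is new, unique, unknown or untested is made for them only; others in the source may bear on it.

The set comprises three measured compounds and one that still awaits its number. Compound 1 `CC(C)(C)OC(=O)NCCCCNCCCN(Cc1ccsc1)Cc1ccsc1`, compound 2 `NCCCCNCCCN(Cc1ccccc1)Cc1ccccc1` and compound 3 `CC(C)(C)OC(=O)NCCCCN(CCCN(Cc1ccc(F)cc1)Cc1ccc(F)cc1)CCCN(Cc1ccc(F)cc1)Cc1ccc(F)cc1` were all examined in an ADME assay on RAW264.7 cells (Mus musculus) for cytotoxicity, read by resazurin assay, with a stated time of 48 h; on this read-out higher numbers stand for lower toxicity in this test and lower numbers for higher toxicity in this test. In this assay compound 1 gives 16400 nM, compound 2 gives 17700 nM and compound 3 gives 12000 nM. Compound 3 thus sits close to the other two, and the gaps from compound 3 to compound 1 and to compound 2 both fall within the usual scatter of repeated measurements, so the three numbers cannot be told apart with confidence.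

Compound 4 `NC1CCC(N(CCCN(Cc2ccc(F)cc2)Cc2ccc(F)cc2)CCCN(Cc2ccc(F)cc2)Cc2ccc(F)cc2)CC1` is derived from compound 3 by a single change: 4-aminocyclohexyl in place of 4-((tert-butoxycarbonyl)amino)butyl on an amine nitrogen. Because compound 2, which also carries a free amine, gives 17700 nM in this assay, no step beyond the scatter is expected here. The step from compound 3 to compound 4 is estimated at a 1.2-fold lower number from compound 3 to compound 4 (0.08 log units; within the scatter), in no firm direction. Compound 4 is therefore expected to give about 10000 nM in this assay, within a range from 4000 nM to 25000 nM.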

Compound 4, half-maximal cytotoxic concentration: 4500 nM
For compound 4 the middle estimate is 2.2-fold (0.35 log units) above the measured one; the range from low to high includes it.
By their numbers in this assay, from the lowest: compound 4; then compounds 3, 1 and 2 (each within the scatter of the next).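

For the compounds shown here, replacing 4-((tert-butoxycarbonyl)amino)butyl with 4-aminocyclohexyl on this amine nitrogen gives the only single-place step in this assay, and it lies beyond the scatter: a 2.7-fold lower number from compound 3 to compound 4 (0.43 log units; beyond the scatter). This shows that the group at this position can shift the number, which compounds 1, 2 and 3 could not show, since their values lie within the scatter of one another and no two of them form a single-place pair. No available data bear on the reason for this step.

The change removes the tert-butoxycarbonyl group and brings in a six-membered carbon ring in one move, so the compounds shown do not separate these two contributions. A plain 4-aminobutyl group or a 4-((tert-butoxycarbonyl)amino)cyclohexyl group on the same nitrogen would tell them apart.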